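The source may report more compounds than this note shows. Statements on the series, on what has been measured and on what is new or still open speak of the compounds shown alone.

Going by the values given here, in a physicochemical assay for solubility, measured as kinetic solubility (a lower number here means a less soluble compound, a higher number a more soluble compound), compound 3 `CCC/N=C1\S/C(=C\c2ccc(O)c(C#N)c2)C(=O)N1c1ccccc1C` gives 220000 nM, the highest number so far, ahead of compound 1 `CCC/N=C1\S/C(=C\c2ccc(O)cc2)C(=O)N1c1ccccc1C` at 79000 nM and compound 2 `CCC/N=C1\S/C(=C\c2ccc(O)c(C(F)(F)F)c2)C(=O)N1c1ccccc1C` at 14000 nM. Compound 4 `CCC/N=C1\S/C(=C\c2ccc(O)c(C(C)C)c2)C(=O)N1c1ccccc1C` changes one place: isopropyl in place of cyano on an aromatic carbon. Among the compounds with values here, three measured steps bear on this. Cyano in place of hydrogen gave a 2.8-fold higher number from compound 1 to compound 3 (0.44 log units; beyond the scatter), trifluoromethyl in place of hydrogen gave a 5.6-fold lower number from compound 1 to compound 2 (0.75 log units; beyond the scatter), and cyano in place of trifluoromethyl gave a 16-fold higher number from compound 2 to compound 3 (1.20 log units; beyond the scatter). Isopropyl itself is untested here, so taking compound 2 as the closest guide is a judgement. The step expected in this assay is large and downward, estimated as a 16-fold lower number from compound 3 to compound 4 (1.20 log units; beyond the scatter). Compound 4 is estimated at 14000 nM, within a range of 4000 nM to 45000 nM.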

Compound 4, solubility: 79000 nM
Compound 4: the middle estimate sits 5.6-fold (0.75 log units) below what was measured; the whole stated range lies below it.
By their numbers in this assay, from the lowest: compound 2; then compounds 1 and 4 (each within the scatter of the next); then compound 3.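

In this assay, isopropyl on this aromatic carbon, ortho to the hydroxy group, leaves the reading where hydrogen puts it, with no change at the digits printed from compound 1 to compound 4 (within the scatter). Trifluoromethyl and isopropyl therefore do not behave alike at this position, as a 5.6-fold higher number from compound 2 to compound 4 (0.75 log units; beyond the scatter) shows, while cyano stays ahead of isopropyl, with a 2.8-fold lower number from compound 3 to compound 4 (0.44 log units; beyond the scatter). No measurement here explains these steps. The compounds shown leave open how an amine or a carboxylic acid on this carbon would read in this assay. They also leave open whether these steps hold with a longer chain.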